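Methylating the Ring Amide Nitrogen of Compound 2

This account rests on a few compounds, and the source may have more. Where it says the series, first, only, none or still open, it means among the compounds named here.

Three compounds have been measured in an assay on CHO-K1 cells for displacement of a labelled ligand from melanin-concentrating hormone receptor 1 (Homo sapiens), read by scintillation proximity assay, with a stated time of 2 h; on this read-out lower numbers stand for stronger inhibition and higher numbers for weaker inhibition:
compound 1 `Cc1nc(NCCNC(=O)C2CC2)nc2ccc(NC(=O)/C=C/c3ccc(OC(F)(F)F)cc3)cc12` gives 61 nM;
compound 2 `Cc1nc(N2CCC(N3CCNC3=O)CC2)nc2ccc(NC(=O)/C=C/c3ccc(OC(F)(F)F)cc3)cc12` gives 66 nM;
compound 3 `Cc1nc(NCCNS(C)(=O)=O)nc2ccc(NC(=O)/C=C/c3ccc(OC(F)(F)F)cc3)cc12` gives 169 nM.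

Among these three numbers compound 2 stands second highest. Its nearest neighbour is compound 1, with a 1.1-fold higher number from compound 1 to compound 2 (0.03 log units; within the scatter), so the two are not distinguishable here. Its furthest neighbour is compound 3, with a 2.6-fold higher number from compound 2 to compound 3 (0.41 log units; beyond the scatter), a modest step; the parallel comparison a 2.8-fold higher number from compound 1 to compound 3 (0.44 log units; beyond the scatter) is of similar size.

Compound 4 `Cc1nc(N2CCC(N3CCN(C)C3=O)CC2)nc2ccc(NC(=O)/C=C/c3ccc(OC(F)(F)F)cc3)cc12` differs from compound 2 by methyl in place of hydrogen on an amide-type nitrogen in a ring. Within the data shown here, none of the measured steps touches this nitrogen: the steps to compound 3 replace the whole side chain or the group on its terminal amine, and the step from compound 1 to compound 2 exchanges one side chain for another. No measured step therefore bears directly on the change, and the data give no reason to expect a step in this assay beyond the scatter in either direction.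

Compound 4 is accordingly expected to give about 80 nM, with a range from 35 nM to 180 nM. That estimate means a step of a 1.2-fold higher number from compound 2 to compound 4 (0.08 log units; within the scatter).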

Compound 4, half-maximal inhibitory concentration: 21 nM
Estimate against measurement, compound 4: 3.8-fold (0.58 log units) above; the whole stated range lies above it.
By their numbers in this assay, from the lowest: compound 4; then compounds 1 and 2 (each within the scatter of the next); then compound 3.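

In this assay, methyl in place of the amide hydrogen gives a 3.1-fold lower number from compound 2 to compound 4 (0.50 log units; beyond the scatter), so this nitrogen in the 2-oxoimidazolidin-1-yl ring is a place where one added carbon moves the number beyond the scatter, towards stronger inhibition. The earlier steps shown here exchanged whole side chains or the group on a terminal amine and left this nitrogen unchanged; this step shows that the amide hydrogen is not required for inhibition in this pair. Nothing in the available data accounts for the size or direction of this step.

The compounds shown leave open whether an ethyl group or a longer chain on this nitrogen would extend the step or reverse it. They also leave open whether methyl on the side-chain amide nitrogen of compound 1 would produce a similar step.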